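From 4-fluorophenyl to 3-chlorothiophen-2-yl on the shared core

The compounds below may be only part of what the source reports. "The series", "measured", "known", "first", "only" and "open" are said of these compounds alone.

In an ADME assay on microsomes from liver (Homo sapiens) for metabolic stability, with a stated time of 10 min, tested at 0.5 uM (a higher number here means that more of the compound is left, a lower number that less of the compound is left), compound 2 `Cc1noc(C)c1[C@@H]1C[C@@](C)(c2ccccc2)N=C(N)S1` gives 86%, compound 3 `Cc1noc(C)c1[C@@H]1C[C@@](C)(c2ccc(F)cc2)N=C(N)S1` gives 73% and compound 1 `Cc1noc(C)c1[C@@H]1C[C@@](C)(c2ccc(F)cc2F)N=C(N)S1` gives 24%. Compound 3 therefore stands second highest of the three, with compound 2 above it and compound 1 far lower.

Compound 4 `Cc1noc(C)c1[C@@H]1C[C@@](C)(c2sccc2Cl)N=C(N)S1` differs from compound 3 at one place: 3-chlorothiophen-2-yl in place of 4-fluorophenyl on a saturated ring carbon. In words, 3-chlorothiophen-2-yl stands in place of 4-fluorophenyl on a saturated ring carbon, next to the ring nitrogen.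

Within the data shown here, no measured step exchanges the whole aromatic ring, so the evidence is indirect. Two steps involve fluoro and hydrogen on an aromatic carbon. The first, a number 13 percentage points lower from compound 2 to compound 3 (beyond the scatter), is modest. The second, a number 49 percentage points higher from compound 1 to compound 3 (beyond the scatter), is large. Together they show that single changes on this aromatic ring can shift the number in this assay well beyond the scatter, and that both fluoro-bearing compounds lie lower than the compound without fluoro. The three compounds offer no case against this, but none carries chloro or a thiophene, so the direction is only a leaning. A modest to large fall is expected, with wide uncertainty.

The expected step is a number 18 percentage points lower from compound 3 to compound 4 (beyond the scatter). The estimated value for compound 4 is 55%, within an expected range of 30% to 80%.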

Compound 4, percent of the compound remaining: 11%
Estimate against measurement, compound 4: 44 percentage points above; measured number below the stated range.
By their numbers in this assay, from the lowest: compound 4; then compound 1; then compound 3; then compound 2.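

In this assay, exchanging the whole aromatic ring on this saturated ring carbon, next to the ring nitrogen, gives a larger step than either fluoro exchange: a number 62 percentage points lower from compound 3 to compound 4 (beyond the scatter), and a number 75 percentage points lower from compound 2 to compound 4 (beyond the scatter). A low number at this position is therefore not confined to the fluoro-bearing phenyl compounds: compound 4, with a five-membered aromatic ring bearing chloro, gives 11%, and it now ranks lowest of the four, under compound 1 at 24%, while the unsubstituted phenyl of compound 2 remains highest and none of the four goes against that order. No measurement shown bears on why the number falls with this exchange.

The compounds shown leave open how much of the fall belongs to the thiophene ring and how much to the chloro, since both enter together in a single step. Also open, as far as these compounds go, is whether a thiophene without chloro, a chlorophenyl, or a methoxy or nitrile on the phenyl ring would keep the number closer to that of compound 2 at 86%.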